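Two fused cores, one aryl swap, and a missing number

The source may report more compounds than this note shows. Statements on the series, on what has been measured and on what is new or still open speak of the compounds shown alone.

Compound 1 `O=C1C2CCCN2C(=O)N1CN1CCN(c2ccc(F)cc2)CC1` and compound 2 `O=C1C2CCCN2C(=O)N1CN1CCN(c2ccc([N+](=O)[O-])cc2)CC1` share one core, while compound 3 `O=C1C2CCCCN2C(=O)N1CN1CCN(c2ccc(F)cc2)CC1` and compound 4 `O=C1C2CCCCN2C(=O)N1CN1CCN(c2ccc([N+](=O)[O-])cc2)CC1` share another; how the two cores differ is not broken down here. In an assay on isolated protein for binding affinity to Adrenergic receptor alpha-1 (Rattus norvegicus), read by radioligand binding (on this read-out lower numbers stand for stronger inhibition and higher numbers for weaker inhibition), compound 1 gives only a limit, > 1000 nM. In this assay compound 2 likewise gives only a limit, > 10000 nM. Within the data shown here, compound 3 is the single compound with a number, giving 869 nM in this assay.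

The change from compound 1 to compound 2 is nitro in place of fluoro on an aromatic carbon. Its size is a step that the two limits leave unreadable from compound 1 to compound 2, which cannot be read because the limit of > 1000 nM in this assay, at which 1 of the 3 values shown sits, and the limit of > 10000 nM in this assay, at which 1 of the 3 values shown sits, bound both ends. The change from compound 3 to compound 4 is the same one, (nitro in place of fluoro on an aromatic carbon), made on the other core.

What can be expected of compound 4 therefore rests on little: compound 3 supplies the starting point with 869 nM, and compound 2, sitting at > 10000 nM after the same change, hints that the nitro compound may well sit at a limit too. The step from compound 3 to compound 4 is expected to be a 3.5-fold higher number from compound 3 to compound 4 (0.54 log units; beyond the scatter). Compound 4 is estimated to give about 3000 nM in this assay, most likely between 800 nM and 15000 nM, with a real chance that only a limit is reported.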

Compound 4, inhibition constant: > 10000 nM
Compound 4: only a limit was reported (the forecaster's own chance of this, stated with the estimate: 50%); middle value at least 3.3-fold (0.52 log units) away from the limit.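

Made on the core of compound 3, nitro in place of fluoro gives an at least 11-fold higher number from compound 3 to compound 4 (1.06 log units; beyond the scatter) in this assay, and with a limit at its upper end, the true step could be larger still. The matching step on the other core, from compound 1 to compound 2, cannot be read, so the two steps cannot be compared in size, and the data do not show that the change carries over from one core to the other by the same amount. What the two cores do have in common is only that both nitro compounds, compound 2 and compound 4, end at the same limit and not at a number: the limit of > 10000 nM in this assay, at which 2 of the 4 values shown sit.

From the compounds shown here alone, whether an amine, a methoxy group or a carboxylic acid on the same aromatic carbon would give a number in this assay on either core remains open. Also open is what a longer chain would do in place of the link that joins the core to the rest of each molecule, since all the compounds shown carry the same link.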